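The source may report more compounds than this note shows. Statements on the series, on what has been measured and on what is new or still open speak of the compounds shown alone.

Measured in a functional assay on SK-OV-3 cells (Homo sapiens) for cytotoxicity; on this read-out higher numbers stand for weaker inhibition of growth and lower numbers for stronger inhibition of growth:
- compound 1 `COc1ccc(C2=C(c3ccc(SC)cc3)CC3CCCN3C2=O)cc1O`: > 100000 nM (a limit, not a number)
- compound 2 `CSc1ccc(C2=C(c3ccc(F)c(C)c3)C(=O)N3CCCC3C2)cc1`: 300 nM
- compound 3 `CSc1ccc(C2=C(c3ccc(O)c(O)c3)C(=O)N3CCCC3C2)cc1`: 80000 nM

Of the two true numbers, that of compound 3 is the higher, and the gap is large: a 270-fold higher number from compound 2 to compound 3 (2.43 log units; beyond the scatter).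

Compound 4 `COc1ccc(C2=C(c3ccc(SC)cc3)CC3CCCN3C2=O)cc1` has 4-methoxyphenyl in place of 3,4-dihydroxyphenyl on a double-bonded ring carbon.

Two measured steps change the group on this same carbon. These are an at least 330-fold lower number from compound 1 to compound 2 (2.52 log units; beyond the scatter) and a 270-fold higher number from compound 2 to compound 3 (2.43 log units; beyond the scatter), and both are large. Among these three compounds, the two with a hydroxyl on this ring, compound 1 and compound 3, give weak growth inhibition, while compound 2, without one, gives much stronger inhibition. The step of an at least 1.2-fold lower number from compound 1 to compound 3 (0.09 log units; that floor lies within the scatter) stays within the scatter at its floor, so it adds little. Compound 4 also lacks a hydroxyl on this ring, but its group differs from that of compound 2, so a somewhat smaller gain is expected.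

The expected change is an 80-fold lower number from compound 3 to compound 4 (1.90 log units; beyond the scatter), towards stronger inhibition. For compound 4 the estimated value is 1000 nM, with an expected range from 150 nM to 15000 nM.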

Compound 4, concentration for 50% growth inhibition: 3000 nM
Beside the measured number, compound 4's estimate is 3.0-fold (0.48 log units) below it, and the stated range covers the measured number.
By their numbers in this assay, from the lowest: compound 2; then compound 4; then compound 3. At a limit, above all of these: compound 1.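

Here a single hydroxyl on the ring is the only change, and in this assay removing it gives a large gain: an at least 33-fold lower number from compound 1 to compound 4 (1.52 log units; beyond the scatter). This step is only a floor, as compound 1 stands at a limit and not at a true number: the limit of > 100000 nM in this assay, at which 1 of the 4 values shown sits. With 4-methoxyphenyl on this carbon the result is a 27-fold lower number from compound 3 to compound 4 (1.43 log units; beyond the scatter), but also a 10-fold higher number from compound 2 to compound 4 (1.00 log units; beyond the scatter), so lacking a hydroxyl on this ring does not by itself match 4-fluoro-3-methylphenyl.

The compounds shown leave open whether the fluorine or the methyl of 4-fluoro-3-methylphenyl accounts for this difference, as the two always appear together here. They also leave open how an amine or a carboxylic acid on this ring would compare with the hydroxyl.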